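Swapping trifluoromethyl for chloro on a urea aryl group

The source may hold more compounds than are shown below. What is called first, only, known or untested is meant among the compounds shown, and "the series" means these compounds.

Compounds measured so far:
compound 1, `O=C(Nc1cccc(-n2cc(-c3ccncc3)c(-c3cc(O)cc(Cl)c3)n2)c1)Nc1ccc(Cl)c(Cl)c1`, 110%
compound 2, `COc1cc(Cl)cc(-c2nn(-c3cccc(NC(=O)Nc4ccc(Cl)c(C(F)(F)F)c4)c3)cc2-c2ccncc2)c1`, 94%

Both compounds were tested in a functional assay on HCC 2998 cells (Homo sapiens) for inhibition, read by sulforhodamine B assay, with a stated time of 48 h, tested at 0.1 uM; on this read-out lower numbers stand for a stronger effect and higher numbers for a weaker effect at the one concentration tested. Compound 1 gives 110%, while compound 2 gives 94%, the lower of the two numbers; the gap between them is beyond the usual scatter, so compound 2 shows the stronger effect of the pair. The two structures differ in more than one place, so no single change can be tied to that gap.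

Compound 3, `COc1cc(Cl)cc(-c2nn(-c3cccc(NC(=O)Nc4ccc(Cl)c(Cl)c4)c3)cc2-c2ccncc2)c1`, has not yet been measured. It is derived from compound 2 by one change: chloro in place of trifluoromethyl on an aromatic carbon. Among the compounds with values here, since no measured pair isolates this change, the size of its effect is unknown. The step of a number 5 percentage points higher from compound 2 to compound 3 (within the scatter) is expected to stay within the scatter, with no clear direction. Compound 3 is therefore estimated at 99%, between 84% and 114%.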

Compound 3, a percentage reported as activity, at one concentration (the size of the read-out at that concentration, not a potency): 96%
The estimate for compound 3 lay 3 percentage points above the measured number, and the stated range covers the measured number.
By their numbers in this assay, from the lowest: compounds 2 and 3 (each within the scatter of the next); then compound 1.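

In this assay, chloro in place of trifluoromethyl gives a number 2 percentage points higher from compound 2 to compound 3 (within the scatter), so at this place on the urea aryl group, ortho to a chloro group, these two groups cannot be told apart at the one concentration tested. Compound 3 also isolates a second place, where methyl in place of hydrogen on an oxygen on an aromatic ring gives a number 14 percentage points lower from compound 1 to compound 3 (beyond the scatter), a modest step that, unlike the first, lies beyond the scatter. Nothing measured here offers an explanation for either step.

Going by these compounds, it remains open whether an amine or a nitrile at the urea aryl position would also stay within the scatter of these two groups. It is also unknown how a longer chain on that oxygen, such as ethyl or propyl, would compare with methyl.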